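Benzoyl in place of 4-chlorobenzyl on a ring nitrogen

A few compounds are considered here, and "the series" means these few. Any claim that something is new, unique, unknown or untested is made for them only; others in the source may bear on it.

Of the compounds shown here, three sharing one core have been measured in a physicochemical assay for solubility, with a stated time of 3 days, at pH 2; on this read-out lower numbers stand for lower solubility and higher numbers for higher solubility. Compound 1 `NC(=O)c1ccc2[nH]c(-c3ccc(OCCC4CCCCN4Cc4ccccc4)cc3)nc2c1` gives > 400000 nM, which is a limit of the assay and not a number. Compound 2 `Cc1ccc(CN2CCCCC2CCOc2ccc(-c3nc4cc(C(N)=O)ccc4[nH]3)cc2)cc1` gives > 400000 nM, again a limit. Compound 3 `NC(=O)c1ccc2[nH]c(-c3ccc(OCCC4CCCCN4Cc4ccc(Cl)cc4)cc3)nc2c1` gives > 400000 nM, also a limit, so it has no exact position on the scale. All three readings stand together: the limit of > 400000 nM in this assay, at which 3 of the 3 values shown sit.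

Compound 4 `NC(=O)c1ccc2[nH]c(-c3ccc(OCCC4CCCCN4C(=O)c4ccccc4)cc3)nc2c1` differs from compound 3 in one place, with benzoyl in place of 4-chlorobenzyl on an amine nitrogen in a ring. Among the measured compounds shown here, three measured steps bear on this only loosely: a step that the two limits leave unreadable from compound 1 to compound 2, a step that the two limits leave unreadable from compound 1 to compound 3 and a step that the two limits leave unreadable from compound 2 to compound 3. Each of them swaps a group on an aromatic carbon, whereas this change falls on the amine nitrogen, and none offers a size to carry over.

Compound 3 is a limit at > 400000 nM, so the expected direction in this assay is downward, with the size largely a guess. The estimated change is an at least 2.6-fold lower number from compound 3 to compound 4 (0.42 log units; beyond the scatter). For compound 4 the expected value is 150000 nM, with an estimated range from 20000 nM to 400000 nM.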

Compound 4, solubility: 28000 nM
Compound 4: the middle estimate sits 5.4-fold (0.73 log units) above what was measured; measured number inside the range.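

In this assay the swaps on the aromatic ring of the benzyl group gave steps that cannot be read, whereas the change on the amine nitrogen in the ring gives the first readable drop in this set, with benzoyl in place of 4-chlorobenzyl producing an at least 14-fold lower number from compound 3 to compound 4 (1.15 log units; beyond the scatter) on this read-out. The other two pairs agree, since benzoyl in place of 4-methylbenzyl gives an at least 14-fold lower number from compound 2 to compound 4 (1.15 log units; beyond the scatter) and benzoyl in place of benzyl gives an at least 14-fold lower number from compound 1 to compound 4 (1.15 log units; beyond the scatter), the last pair keeping the unsubstituted aromatic ring and gaining a carbonyl. All three sizes are minimum figures, and the starting compounds 1, 2 and 3 give a limit and not a number: the limit of > 400000 nM in this assay, at which 3 of the 4 values shown sit.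

Going by these compounds, how far the real gap extends therefore stays open, and so does how compounds 1, 2 and 3 rank among themselves. On these data alone, it is also open whether this drop belongs to the benzoyl group alone or would also follow from an acetyl group, a sulfonyl group or a plain methyl on the same ring nitrogen.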